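The source may hold more compounds than are shown below. What is called first, only, known or untested is meant among the compounds shown, and "the series" means these compounds.

Measured in a functional assay on A-375 cells (Homo sapiens) for antiproliferative activity, read by MTT assay, with a stated time of 24 h, tested at 11.11 ug/mL (a lower number here means a weaker effect, a higher number a stronger effect of the compound at the concentration tested), so far:
compound 1 `CCOc1ccc2nc(C(=O)Nc3c(F)cc(-c4cccc(F)c4)cc3F)c(C)c(O)c2c1` gives 15.3%;
compound 2 `CCc1ccc2nc(C(=O)Nc3c(F)cc(-c4cccc(F)c4)cc3F)c(C)c(C(=O)O)c2c1` gives 38.9%;
compound 3 `Cc1c(C(=O)Nc2c(F)cc(-c3cccc(F)c3)cc2F)nc2ccc(F)cc2c1C(=O)O` gives 36.3%.

Compound 3 stands second highest of the three numbers in this assay. Its nearest neighbour is compound 2, and the step of a number 2.6 percentage points lower from compound 2 to compound 3 (within the scatter) is within the scatter. Compound 1 sits well below both, but it differs from compound 3 in more than one place, so only the two values themselves can be compared.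

Compound 4 `CCOc1ccc2nc(C(=O)Nc3c(F)cc(-c4cccc(F)c4)cc3F)c(C)c(C(=O)O)c2c1` is compound 3 after the change (ethoxy in place of fluoro on an aromatic carbon). For the measured compounds named here, the only single step on that aromatic carbon, a number 2.6 percentage points lower from compound 2 to compound 3 (within the scatter), was within the scatter, so no step beyond the scatter is expected from compound 3 to compound 4. Compound 4 is estimated at 37%, with a range from 22% to 50%, which means an expected step of a number 0.7 percentage points higher from compound 3 to compound 4 (within the scatter).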

Compound 4, a percentage reported as inhibition, at one concentration (the size of the read-out at that concentration, not a potency): 48.3%
Estimate against measurement, compound 4: 11.3 percentage points below; the range from low to high includes it.
By their numbers in this assay, from the lowest: compound 1; then compounds 3, 2 and 4 (each within the scatter of the next, the first and the last beyond it).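

Ethoxy in place of fluoro on this aromatic carbon gives a number 12 percentage points higher from compound 3 to compound 4 (beyond the scatter), whereas ethoxy in place of ethyl gives a number 9.4 percentage points higher from compound 2 to compound 4 (within the scatter), so this position accepts ethoxy without any loss in the read-out. Carboxy in place of hydroxy at the other changed carbon gives a number 33 percentage points higher from compound 1 to compound 4 (beyond the scatter), which shows for the first time, with ethoxy held fixed, how much that second place matters. No measurement shown gives a cause for these steps.

As far as these compounds go, it remains open how a longer chain such as butoxy, or an amine, would read on the ethoxy-bearing carbon.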